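Methoxymethyl replacing methyl beside the acid in the series

A few compounds are considered here, and "the series" means these few. Any claim that something is new, unique, unknown or untested is made for them only; others in the source may bear on it.

Compound 1 `CC(C)(CCC/C=C(\c1ccccc1)c1cccnc1)C(=O)O` is measured in an assay (Equus caballus) for inhibition of Thromboxane-A synthase (Homo sapiens), using microsomes (a higher number here means a weaker inhibitor, a lower number a stronger inhibitor), and gives 21 nM. Among the three measured compounds it has the lowest number. Compound 2 `CC(C)(CCC/C=C(/c1ccccc1)c1cccnc1)C(=O)O` gives 30 nM in this assay, and the step of a 1.4-fold higher number from compound 1 to compound 2 (0.15 log units; within the scatter) stays within the scatter; the only difference between them is the fact that compounds 1 and 2 differ only in the configuration as drawn, so this pair says nothing about changes along the saturated chain. Among the compounds with values here, compound 3 `O=C(O)CCCC/C=C(/CCCc1ccccc1)c1cccnc1` gives 65 nM in this assay, a number beyond the scatter of compound 1, but compound 3 differs from compound 1 in more than one place, and no single step connects them.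

Compound 4 `COCC(CCC/C=C(\c1ccccc1)c1cccnc1)C(=O)O` is not yet measured. Relative to compound 1 the change is 1-carboxy-2-methoxyethyl in place of 1-carboxy-1-methylethyl on a saturated chain carbon, three bonds along the chain from a double-bonded chain carbon. Neither measured step bears on this change: the step from compound 1 to compound 2 concerns configuration only, and compound 3 is not a one-place neighbour of either. The change adds one ether oxygen while removing a methyl on the same chain carbon, a modest reshaping of the 1-carboxy end of the chain. Within the data shown here, with no precedent, compound 4 is expected to stay close to compound 1, and the expected step of a 1.2-fold higher number from compound 1 to compound 4 (0.08 log units; within the scatter) lies within the scatter. Compound 4 is therefore estimated at 25 nM in this assay, with a range from 8 nM to 80 nM.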

Compound 4, half-maximal inhibitory concentration: 41 nM
For compound 4 the middle estimate is 1.6-fold (0.21 log units) below the measured one; the measured number falls inside the stated range.
By their numbers in this assay, from the lowest: compounds 1, 2, 4 and 3 (each within the scatter of the next, the first and the last beyond it).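

In this assay the series now has a one-place step at the end of the chain that carries the carboxylic acid, rather than one of configuration alone: replacing 1-carboxy-1-methylethyl with 1-carboxy-2-methoxyethyl gives a 2.0-fold higher number from compound 1 to compound 4 (0.29 log units; within the scatter). At this position, on a saturated chain carbon three bonds along the chain from a double-bonded chain carbon, the swap of a methyl for methoxymethyl therefore leaves the number within the scatter, which is a reading of this single pair and not a trend. Nothing in the data on these compounds bears on the reason for this step, and the pair of compounds 1 and 2 does not touch this position.

This step combines two differences, the loss of one methyl and the addition of an ether oxygen, and the compounds shown do not separate them; a lone methyl, a hydroxymethyl or an ethyl at this carbon would do so. Also open, going by these compounds, are whether a longer ether such as ethoxymethyl reads the same way, and whether methoxymethyl behaves alike on the configuration of compound 2 or on the chains of compound 3.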